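The compounds below may be only part of what the source reports. "The series", "measured", "known", "first", "only" and "open" are said of these compounds alone.

Measured so far:
compound 1, `Cc1ccc(C(=O)NCN2CCC(c3cccc[n+]3[O-])CC2)cc1C`: 38 nM
compound 2, `Cc1cccc(NC(=O)CN2CCC(c3cccc(O)c3)CC2)c1`: 8 nM

In a functional assay on HEK293 cells for agonist activity at D(4) dopamine receptor (Homo sapiens), read by FLIPR (on this read-out lower numbers stand for an effect already at smaller amounts and higher numbers for an effect only at larger amounts of compound), compound 1 gives 38 nM, the higher of the two numbers in the series. Compound 2 gives 8 nM in this assay, a lower number by a margin beyond the scatter of repeated measurements. Among the compounds with values here, no two measured compounds differ in a single place, so no measured step exists to guide the change from compound 1 to compound 3.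

Compound 3, `Cc1cccc(C(=O)NCN2CCC(c3cccc[n+]3[O-])CC2)c1`, differs from compound 1 only in the aromatic ring at one end of the shared core: hydrogen in place of methyl on an aromatic carbon. The rest of the molecule, including the charged ring at the other end, is unchanged.

Within the data shown here, with no comparable step, the change is expected to give in this assay a step of small size, most likely within the scatter, with a slight lean toward a higher number; the step from compound 1 is estimated as a 1.3-fold higher number from compound 1 to compound 3 (0.12 log units; within the scatter). For compound 3 the expected value in this assay is 50 nM, with a range of 15 nM to 160 nM.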

Compound 3, half-maximal effective concentration: 89 nM
The estimate for compound 3 lay 1.8-fold (0.25 log units) below the measured number; the range from low to high includes it.
By their numbers in this assay, from the lowest: compound 2; then compound 1; then compound 3.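

In this assay, within the data shown here, the step from methyl to hydrogen gives a 2.3-fold higher number from compound 1 to compound 3 (0.37 log units; beyond the scatter), the first comparison that isolates a single place. The methyl on this aromatic carbon, ortho to a methyl group and para to a large group, therefore registers on this read-out: the 3,4-dimethylphenyl compound carries the lower number and the 3-methylphenyl compound the higher, by a modest margin beyond the scatter. Nothing available bears on the origin of this step, so it stands as an observation from one pair, with no explanation attached.

On these data alone, whether a larger group at this carbon, such as ethyl, methoxy or chlorine, would take the number lower than in compound 1, leave it unchanged or raise it remains open, since methyl and hydrogen give only two points at this position. Also open, as far as these compounds go, is whether the same methyl-to-hydrogen step would hold on a different core, as compound 2 differs from compound 1 in more than one place and so cannot address this question.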